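Working notes on an amide ester series

A few compounds are considered here, and "the series" means these few. Any claim that something is new, unique, unknown or untested is made for them only; others in the source may bear on it.

compound 1 `CCOC(=O)CNC(=O)/C=C/c1ccc(O)c(O)c1`: 18600 nM
compound 2 `CCOC(=O)[C@@H](NC(=O)/C=C/c1ccc(O)c(O)c1)C(C)C`: 19600 nM
compound 3 `CCOC(=O)[C@H](C)NC(=O)/C=C/c1ccc(OC(C)=O)c(OC)c1`: 482000 nM

All three were read in a functional assay, read by spectrophotometry, with a stated time of 30 min; on this read-out lower numbers stand for stronger inhibition and higher numbers for weaker inhibition. The change from compound 1 to compound 2 is isopropyl in place of hydrogen on a saturated chain carbon bound to an amide-type nitrogen and a carbonyl carbon, and it made a 1.1-fold higher number from compound 1 to compound 2 (0.02 log units; within the scatter). Compound 3 stands highest of the three; the difference between its core and the core of compound 1 is not broken down here.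

Compound 4 `CCOC(=O)[C@H](CC(C)C)NC(=O)/C=C/c1ccc(OC(C)=O)c(OC)c1` is not yet measured. Its change from compound 3 is isopropyl in place of hydrogen on a saturated chain carbon, two bonds along the chain from an amide-type nitrogen and a carbonyl carbon. This is the same kind of change as from compound 1 to compound 2, not the same: there the carbon is bound to an amide-type nitrogen and a carbonyl carbon, here it sits two bonds along the chain from them.

The expected step is a 1.1-fold lower number from compound 3 to compound 4 (0.03 log units; within the scatter), because a 1.1-fold higher number from compound 1 to compound 2 (0.02 log units; within the scatter) stayed within the scatter. Compound 4 is therefore estimated at 450000 nM, with a range from 150000 nM to 1400000 nM.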

Compound 4, half-maximal inhibitory concentration: > 500000 nM
Compound 4 gave a limit, no number; the forecaster's own chance of this, stated with the estimate: 20%; middle value at least 1.1-fold (0.04 log units) away from the limit.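

In this assay compound 4 gives > 500000 nM, which is a limit of the assay and not a number. The step reads an at least 1.0-fold higher number from compound 3 to compound 4 (0.01 log units; that floor lies within the scatter), and how far the true step lies beyond that floor cannot be read. The result neither shows that the change carries over unaltered from the core of compound 1 to the core of compound 3 nor shows that it behaves differently there: the same change on two cores in this assay, a 1.1-fold higher number (0.02 log units; within the scatter) from compound 1 to compound 2 and an at least 1.0-fold higher number (0.01 log units; that floor lies within the scatter) from compound 3 to compound 4; the limit leaves it open whether they differ

The compounds shown leave open what a longer chain on the same saturated chain carbon would give on either core. They also leave open what a carboxylic acid in place of the ester would give.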